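The source may hold more compounds than are shown below. What is called first, only, known or untested is meant among the compounds shown, and "the series" means these compounds.

Measured so far in a functional assay on MCF7 cells (Homo sapiens) for cytotoxicity, read by MTT assay, with a stated time of 72 h; on this read-out lower numbers stand for stronger inhibition of growth and higher numbers for weaker inhibition of growth:
compound 1 `COc1ccc(CNc2nc([SeH])nc3ccccc23)cc1` gives 42700 nM
compound 2 `CSc1ccc(CNc2nc([SeH])nc3ccccc23)cc1` gives 48100 nM
compound 3 `COc1ccc(CNc2nc(SC)nc3ccccc23)cc1` gives 30900 nM

All three numbers lie within the scatter of one another, so no order among them is claimed. The change from compound 1 to compound 2 is methylsulfanyl in place of methoxy on an aromatic carbon, and it made a step of a 1.1-fold higher number from compound 1 to compound 2 (0.05 log units; within the scatter). Compound 3 carries a different core; against compound 1 the difference is a group of 2 heavy atoms (1 carbon, 1 sulfur; no ring) in place of one selenium atom, on an aromatic carbon, with a step of a 1.4-fold lower number from compound 1 to compound 3 (0.14 log units; within the scatter).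

Compound 4 `CSc1ccc(CNc2nc(SC)nc3ccccc23)cc1` is not yet measured. It differs from compound 3 by methylsulfanyl in place of methoxy on an aromatic carbon. For the measured compounds named here, the place description agrees word for word with the one for the pair compound 1 and compound 2, so this is the same change, made here on the core of compound 3. The expectation for compound 4 rests on the single earlier occurrence, the step of a 1.1-fold higher number from compound 1 to compound 2 (0.05 log units; within the scatter) from compound 1 to compound 2, which stayed within the scatter. Compound 4 is therefore expected to sit close to compound 3, with an estimated step of a 1.1-fold higher number from compound 3 to compound 4 (0.04 log units; within the scatter). The estimate for compound 4 in this assay is 34000 nM, with an expected range from 17000 nM to 68000 nM.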

Compound 4, concentration for 50% growth inhibition: 47300 nM
Compound 4: the middle estimate sits 1.4-fold (0.14 log units) below what was measured; the range from low to high includes it.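

In this assay, methylsulfanyl in place of methoxy on an aromatic carbon gives a 1.5-fold higher number from compound 3 to compound 4 (0.18 log units; within the scatter) and so stays as small on the core of compound 3 as on the core of compound 1:
the same change on two cores in this assay, a 1.1-fold higher number (0.05 log units; within the scatter) from compound 1 to compound 2 and a 1.5-fold higher number (0.18 log units; within the scatter) from compound 3 to compound 4, 1.4-fold (0.13 log units) apart, within the scatter of two such steps

The other change, a group of 2 heavy atoms (1 carbon, 1 sulfur; no ring) in place of one selenium atom on an aromatic carbon, gives a 1.0-fold lower number from compound 2 to compound 4 (0.01 log units; within the scatter) and also carries over without a difference that can be told from scatter: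
the same change on two cores in this assay, a 1.4-fold lower number (0.14 log units; within the scatter) from compound 1 to compound 3 and a 1.0-fold lower number (0.01 log units; within the scatter) from compound 2 to compound 4, 1.4-fold (0.13 log units) apart, within the scatter of two such steps

This shows that on these cores neither change moves the number beyond the scatter, but it does not show that a change with a step beyond the scatter would carry over in the same way, since all four compounds lie too close together to test that.

Going by these compounds, whether an amine, a carboxylic acid or a longer chain in place of methoxy or methylsulfanyl would give a step beyond the scatter remains open. On these data alone, whether the same small steps would hold on a core carrying neither selenium nor methylsulfanyl at the other changed carbon also remains open.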